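A few compounds are considered here, and "the series" means these few. Any claim that something is new, unique, unknown or untested is made for them only; others in the source may bear on it.

Measured in an assay on CHO cells for displacement of a labelled ligand from adenosine receptor A1 (Homo sapiens), read by scintillation counting, with a stated time of 90 min, tested at 1 uM, in the presence of a further agent that is not named here; a higher number here means more inhibition at the concentration tested (going by the name of the read-out), a lower number less inhibition:
compound 1, `CCCn1c(=O)[nH]c2nc(-c3ccc(S(=O)(=O)N4CCN(Cc5ccc(Br)cc5)CC4)cc3)[nH]c2c1=O`, 31%
compound 2, `CCCn1c(=O)[nH]c2nc(-c3ccc(S(=O)(=O)N4CCN(c5ccc(I)cc5)CC4)cc3)[nH]c2c1=O`, 24%
compound 3, `CCCn1c(=O)[nH]c2nc(-c3ccc(S(=O)(=O)N4CCN(c5ccc(Cl)cc5F)CC4)cc3)[nH]c2c1=O`, 9%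

Compound 3 stands lowest of the three, beyond the scatter from both others: a number 22 percentage points lower from compound 1 to compound 3 (beyond the scatter) and a number 15 percentage points lower from compound 2 to compound 3 (beyond the scatter), while a number 7 percentage points lower from compound 1 to compound 2 (within the scatter). Compound 4, `CCCn1c(=O)[nH]c2nc(-c3ccc(S(=O)(=O)N4CCN(c5ccccc5F)CC4)cc3)[nH]c2c1=O`, differs from compound 3 by hydrogen in place of chloro on an aromatic carbon. Among the compounds with values here, no measured step isolates a halogen on that ring; the steps into compound 3 each swap the whole group on the amine nitrogen, so they bear on this change only loosely. Within the data shown here, with no direct precedent, the expected step is small: a number 2 percentage points lower from compound 3 to compound 4 (within the scatter), none beyond the scatter. Compound 4 is therefore estimated at 7%, in the range -5% to 20% in this assay.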

Compound 4, a percentage reported as inhibition, at one concentration (the size of the read-out at that concentration, not a potency): 13%
Estimate against measurement, compound 4: 6 percentage points below; measured number inside the range.
By their numbers in this assay, from the lowest: compounds 3 and 4 (each within the scatter of the next); then compounds 2 and 1 (each within the scatter of the next).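

In this assay, within the data shown here, the step of a number 4 percentage points higher from compound 3 to compound 4 (within the scatter) is the first to isolate a halogen on this ring: at this place, chloro gives way to hydrogen without a readable change. The 2-fluorophenyl group still sits apart from the other two groups on the amine nitrogen, with a number 11 percentage points lower from compound 2 to compound 4 (beyond the scatter) and a number 18 percentage points lower from compound 1 to compound 4 (beyond the scatter) as whole-group swaps. Nothing at hand explains these steps.

Open: whether a methoxy group or an amine at this place would move the number beyond the scatter, and whether plain phenyl on the amine nitrogen would read differently from 2-fluorophenyl.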